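This account rests on a few compounds, and the source may have more. Where it says the series, first, only, none or still open, it means among the compounds named here.

Measured in a functional assay on Ehrlich cells (Mus musculus) for inhibition; a lower number here means a stronger inhibitor, a higher number a weaker inhibitor:
Compound 1 `O=C(O)c1cnc2cc(OCc3c(Cl)c(Cl)c(Cl)c(Cl)c3Cl)ccc2c1O` gives 42700 nM
Compound 2 `O=C(O)c1ccc2c(O)c(C(=O)O)cnc2c1` gives 5750000 nM
Compound 3 `CN(C)c1ccc2c(O)c(C(=O)O)cnc2c1` gives 468000 nM

Compound 3 stands second highest of the three. In this assay compound 3 at 468000 nM lies under compound 2 at 5750000 nM on the scale of numbers. Compound 3 also lies over compound 1 at 42700 nM on that scale.

Compound 4 `O=C(O)c1cnc2cc(O)ccc2c1O` has not yet been measured. It carries hydroxy in place of dimethylamino on an aromatic carbon and is otherwise the same as compound 3.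

Going by the values given here, one measured step bears on this change. The step of a 12-fold lower number from compound 2 to compound 3 (1.09 log units; beyond the scatter) is large and beyond the scatter, and it came with dimethylamino in place of carboxy on that same aromatic carbon. It shows that the group at this carbon can move the number considerably. Among the compounds with values here, no measured compound shows what hydroxy does there, so the evidence is indirect. Removing dimethylamino might give back part of the drop seen in that step, though hydroxy is not carboxy, so only part of it is expected. The expected change is a moderate one towards weaker inhibition, an estimated 3.2-fold higher number from compound 3 to compound 4 (0.51 log units; beyond the scatter) in this assay and probably just beyond the scatter. The estimate for compound 4 is 1500000 nM as an expected value, with 400000 nM to 5000000 nM as its expected range.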

Compound 4, half-maximal inhibitory concentration: 912000 nM
Estimate against measurement, compound 4: 1.6-fold (0.22 log units) above; low and high end bracket the measured number.
By their numbers in this assay, from the lowest: compound 1; then compounds 3 and 4 (each within the scatter of the next); then compound 2.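

In this assay, going by these compounds alone, the change of dimethylamino to hydroxy gives a 1.9-fold higher number from compound 3 to compound 4 (0.29 log units; within the scatter) and stays within the scatter, so the first direct comparison of these two groups on this aromatic carbon does not separate them. Hydroxy in place of carboxy gives a 6.3-fold lower number from compound 2 to compound 4 (0.80 log units; beyond the scatter) as a modest step beyond the scatter, which sets beside the large 12-fold lower number from compound 2 to compound 3 (1.09 log units; beyond the scatter) a second replacement of carboxy that also lowers the number. Among the three groups compared on this carbon, carboxy therefore stands apart with the highest number, while dimethylamino and hydroxy, which differ in size and in hydrogen-bond donor count, cannot be told apart.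

Compound 1, with a pentachlorobenzyl ether on the same carbon, gives 42700 nM and so has the lowest number of the set. The compounds shown leave open whether a methoxy group, a longer alkoxy chain or a primary amine on this carbon would give a number nearer to that of compound 1 or to that of compound 4. No measurement here speaks to why these groups give the numbers they do.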